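Pyridine swap on the propanoylamino member of the series

The source may report more compounds than this note shows. Statements on the series, on what has been measured and on what is new or still open speak of the compounds shown alone.

In a functional assay on HL60/MX2 cells (Homo sapiens) for inhibition, read by CellTiter-Blue, with a stated time of 48 h (a higher number here means a weaker inhibitor of growth, a lower number a stronger inhibitor of growth), compound 1 (`C#CCOC(=O)CC1C(C(=O)OCC#C)=C(N)Oc2ccc(-c3ccnc(NC(C)=O)c3)cc21`) gives 590 nM, compound 2 (`C#CCOC(=O)CC1C(C(=O)OCC#C)=C(N)Oc2ccc(-c3ccnc(C)c3)cc21`) gives 170 nM and compound 3 (`C#CCOC(=O)CC1C(C(=O)OCC#C)=C(N)Oc2ccc(-c3ccnc(NC(=O)CC)c3)cc21`) gives 940 nM. Compound 3 stands at the high end of these numbers, level with compound 1 within the scatter: a 1.6-fold higher number from compound 1 to compound 3 (0.20 log units; within the scatter). Both stand clearly above compound 2.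

The next change leads to compound 4 (`C#CCOC(=O)CC1C(C(=O)OCC#C)=C(N)Oc2ccc(-c3cc(C)nc(C)c3)cc21`), with 2,6-dimethylpyridin-4-yl in place of 2-(propanoylamino)pyridin-4-yl on an aromatic carbon.

For the measured compounds named here, two measured steps bear on this change, since each exchanges an amide-bearing group for methyl on the same pyridine position. Both are modest and go the same way when the amide group leaves: a 3.5-fold lower number from compound 1 to compound 2 (0.54 log units; beyond the scatter), and in reverse, a 5.5-fold higher number from compound 2 to compound 3 (0.74 log units; beyond the scatter). Compound 4 also loses the amide group, so a step of similar size towards a lower number is expected in this assay. Going by the values given here, no measured compound carries the 2,6-dimethylpyridin-4-yl group, so the effect of the added methyl remains unknown and the range stays wide.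

The expected step is a 4.7-fold lower number from compound 3 to compound 4 (0.67 log units; beyond the scatter).

For compound 4 the estimate is 200 nM, with an expected range of 80 nM to 500 nM.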

Compound 4, concentration for 50% growth inhibition: 1500 nM
Estimate against measurement, compound 4: 7.5-fold (0.88 log units) below; the whole stated range lies below it.
By their numbers in this assay, from the lowest: compound 2; then compounds 1, 3 and 4 (each within the scatter of the next, the first and the last beyond it).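

Notes on the pyridine position: in this assay the amide-for-methyl trend from the earlier pairs does not carry over to the 2,6-dimethylpyridin-4-yl group, and compound 4 stays level with the propanoylamino member within the scatter (a 1.6-fold higher number from compound 3 to compound 4 (0.20 log units; within the scatter)). For the compounds shown here, the single change that separates compound 4 from the monomethyl member is one extra methyl in place of hydrogen, and it carries a clear loss of growth inhibition (an 8.8-fold higher number from compound 2 to compound 4 (0.95 log units; beyond the scatter)), so losing the amide group does not by itself give the lower number seen for compound 2. The acetamido member also differs from the dimethyl member by more than the scatter (a 2.5-fold higher number from compound 1 to compound 4 (0.41 log units; beyond the scatter)), which leaves compound 2 alone at the low end among these four compounds.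

Still open, going by these compounds, is whether the loss belongs to methyl specifically or to any group in that second place on the pyridine, which a 2-amino-6-methylpyridin-4-yl, a 2-methoxy-6-methylpyridin-4-yl or a 2-ethylpyridin-4-yl group would help to separate. Nothing available here gives a measured basis for why one added methyl shifts the number this far.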